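The source may report more compounds than this note shows. Statements on the series, on what has been measured and on what is new or still open speak of the compounds shown alone.

In a functional assay on A549 cells (Homo sapiens) for antiproliferative activity, read by MTT assay, with a stated time of 24 h (a lower number here means a stronger inhibitor, a higher number a weaker inhibitor), compound 1 `Cc1cc(=O)n2nc(SCc3ccc(F)cc3)nc2[nH]1` gives > 80000 nM, which is a limit of the assay and not a number. Compound 2 `Cc1cc(=O)n2nc(SCc3ccc(C(C)C)cc3)nc2[nH]1` gives 35200 nM. Among the measured compounds shown here, compound 3 `Cc1cc(=O)n2nc(SCc3cccc(C(F)(F)F)c3)nc2[nH]1` gives 72000 nM, the higher of the two actual numbers so far, and the gap to compound 2 lies just beyond the scatter.

The next change leads to compound 4 `Cc1cc(=O)n2nc(SCc3cccc([N+](=O)[O-])c3)nc2[nH]1`: nitro in place of trifluoromethyl on an aromatic carbon. This places nitro in place of trifluoromethyl on an aromatic carbon, meta to a large group.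

For the measured compounds named here, only one measured step bears on this: an at least 2.2-fold lower number from compound 1 to compound 2 (0.35 log units; beyond the scatter), with isopropyl in place of fluoro on an aromatic carbon. Going by the values given here, that step exchanges different groups and starts from the limit of > 80000 nM in this assay, at which 1 of the 3 values shown sits, so it shows only that a change of group can shift the reading by a modest amount. It gives no direction for the nitro exchange, so no shift beyond the scatter is expected in this assay. The estimated change is a 1.2-fold lower number from compound 3 to compound 4 (0.08 log units; within the scatter). For compound 4 the expected value is 60000 nM, with an estimated range of 30000 nM to 90000 nM.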

Compound 4, half-maximal inhibitory concentration: > 80000 nM
Compound 4: a limit, no number; the forecaster's own chance of this, stated with the estimate: 25%; middle value at least 1.3-fold (0.12 log units) from the limit.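

In this assay compound 4 gives > 80000 nM, which is a limit and not a number. Nitro in place of trifluoromethyl, meta to a large group, gives an at least 1.1-fold higher number from compound 3 to compound 4 (0.04 log units; that floor lies within the scatter), so this exchange brings no gain in the reading at this position, although the floor of the step does not separate the two groups. The true size of the step stays unread because the reading of compound 4 ends at a limit, as that of compound 1 does: the limit of > 80000 nM in this assay, at which 2 of the 4 values shown sit.

The compounds shown leave open how isopropyl would read at this same place, and whether an amine or a carboxylic acid there would bring the reading clear of the limit. They also leave open how any change to the shared core would read, since only the groups on the aromatic ring vary.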